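Trifluoromethyl to Cyano: the Same Change in Two Settings

This account rests on a few compounds, and the source may have more. Where it says the series, first, only, none or still open, it means among the compounds named here.

Compound 1 has the structure `CC(=O)/C(=N\Nc1ccccc1C(F)(F)F)N(C)c1cccc(Cl)c1`. In an assay on isolated protein for binding affinity to corticotropin-releasing factor receptor 1 (Homo sapiens) (on this read-out higher numbers stand for weaker inhibition and lower numbers for stronger inhibition), compound 1 gives only a limit of the assay, > 10000 nM. Compound 2, with the structure `CC(=O)/C(=N\Nc1ccccc1C#N)N(C)c1cccc(Cl)c1`, differs from compound 1 by one change, (cyano in place of trifluoromethyl on an aromatic carbon). In this assay compound 2 likewise gives only a limit, > 10000 nM. The step that the two limits leave unreadable from compound 1 to compound 2 therefore cannot be sized, because both values sit at the limit of > 10000 nM in this assay, at which 2 of the 3 values shown sit.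

Compound 3 has the structure `CC(=O)/C(=N\c1ccccc1)NNc1ccccc1C(F)(F)F`. In this assay, among the measured compounds shown here, compound 3 gives 2260 nM, the one value here that is a number rather than a limit. The difference between the core of compound 3 and the core of compound 1 is not broken down here.

Compound 4, not yet measured, has the structure `CC(=O)/C(=N\c1ccccc1)NNc1ccccc1C#N` and differs from compound 3 by cyano in place of trifluoromethyl on an aromatic carbon, the same change as from compound 1 to compound 2. For the measured compounds named here, since that earlier step is unreadable, the expected step of a 1.1-fold higher number from compound 3 to compound 4 (0.04 log units; within the scatter) rests on no sized precedent and is taken as roughly flat. Compound 4 is estimated at 2500 nM, expected between 700 nM and 9000 nM.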

Compound 4, inhibition constant: 1080 nM
The estimate for compound 4 lay 2.3-fold (0.36 log units) above the measured number; low and high end bracket the measured number.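

In this assay, putting cyano in place of trifluoromethyl on the core of compound 3 gives a 2.1-fold lower number from compound 3 to compound 4 (0.32 log units; beyond the scatter), a modest step that lies beyond the usual scatter and points to somewhat stronger inhibition on this core. This result cannot be compared with the same change on the core of compound 1, and that earlier step cannot be read because the values on both sides of it are limits of the assay, not numbers: the limit of > 10000 nM in this assay, at which 2 of the 4 values shown sit. The new step therefore shows that the change can be read and is modest on one core, but it does not show that the change carries from one core to another, in either size or direction.

As far as these compounds go, it remains open how a methoxy group or an amine would compare on the same aromatic carbon of the core of compound 3, since only trifluoromethyl and cyano appear there. From the compounds shown here alone, it is also open whether the step would repeat on a further core where both partners give numbers.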